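The compounds below may be only part of what the source reports. "The series", "measured", "known", "first", "only" and "open" are said of these compounds alone.

In a functional assay on HT-29 cells (Homo sapiens) for inhibition, read by MTT assay, with a stated time of 72 h (a higher number here means a weaker inhibitor of growth, a lower number a stronger inhibitor of growth), compound 1 `O=S(=O)(NCCCNCc1ccccc1Cl)c1cc(C(F)(F)F)cc(C(F)(F)F)c1` gives 20000 nM, and compound 2 `O=S(=O)(NCCCNCc1ccc(Cl)c(C(F)(F)F)c1)c1cc(C(F)(F)F)cc(C(F)(F)F)c1` gives 11000 nM, a change of a 1.8-fold lower number from compound 1 to compound 2 (0.26 log units; within the scatter). Going by the values given here, of the two numbers measured, the one for compound 2 is the smaller, yet its gap to compound 1 lies within the scatter. Compound 3 `O=S(=O)(NCCCNCC1COc2ccccc2O1)c1cc(C(F)(F)F)cc(C(F)(F)F)c1` differs from compound 2 by 2,3-dihydro-1,4-benzodioxin-2-yl in place of 4-chloro-3-(trifluoromethyl)phenyl on a saturated chain carbon bound to an amine nitrogen. Among the compounds with values here, only this single measured step bears on such a change, and it stayed within the scatter, so no step beyond the scatter is expected in this assay. Compound 3 is estimated at 14000 nM, with a range from 5000 nM to 45000 nM. That corresponds to an expected 1.3-fold higher number from compound 2 to compound 3 (0.10 log units; within the scatter).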

Compound 3, concentration for 50% growth inhibition: 2200 nM
Compound 3: middle estimate off by 6.4-fold (0.80 log units), on the high side; the measured number lies below the stated range.
By their numbers in this assay, from the lowest: compound 3; then compounds 2 and 1 (each within the scatter of the next).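

At this place, on a saturated chain carbon bound to an amine nitrogen, exchanging one substituted phenyl for another had stayed within the scatter. In this assay, the 2,3-dihydro-1,4-benzodioxin-2-yl group now gives steps beyond it: a 5.0-fold lower number from compound 2 to compound 3 (0.70 log units; beyond the scatter) and a 9.1-fold lower number from compound 1 to compound 3 (0.96 log units; beyond the scatter). Growth inhibition at this place therefore does depend on the group attached, though nothing available explains this stronger result.

From the compounds shown here alone, whether the two ring oxygens are needed remains open. A 1,2,3,4-tetrahydronaphthalen-2-yl group, with carbon in their place, would test that directly.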